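From 4-Cyanophenyl to 5-Cyanopyridin-2-yl on Vero Cells

The source may report more compounds than this note shows. Statements on the series, on what has been measured and on what is new or still open speak of the compounds shown alone.

Three compounds of one series have been put into an ADME assay on Vero cells (Chlorocebus sabaeus) for cytotoxicity, read by MTT assay, with a stated time of 72 h (on this read-out lower numbers stand for stronger inhibition and higher numbers for weaker inhibition), yet only one of them carries a number-like result. Compound 1 `CN1CCN(c2nc(Oc3ccc(C#N)cc3)nc(-c3ccc(N4C(=O)CSC4c4ccc([N+](=O)[O-])cc4)cc3)n2)CC1` returns "not determined" (no result reported) in this assay. Compound 3 `CN1CCN(c2nc(Oc3ccc(C#N)cn3)nc(-c3ccc(N4C(=O)CSC4c4ccccc4)cc3)n2)CC1` likewise returns "not determined" (no result reported) in this assay. Compound 2 `COc1ccc(C2SCC(=O)N2c2ccc(-c3nc(Oc4ccc(C#N)cc4)nc(N4CCN(C)CC4)n3)cc2)cc1` stands at a limit of the assay rather than at a number: in this assay compound 2 gives > 62.5 ug/mL. Within the data shown here, the position of that result is the limit of > 62.5 ug/mL in this assay, at which 1 of the 3 values shown sits, so the only informative entry in the set is a limit, and no step between two measured compounds can be drawn from it.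

Compound 4 `COc1ccc(C2SCC(=O)N2c2ccc(-c3nc(Oc4ccc(C#N)cn4)nc(N4CCN(C)CC4)n3)cc2)cc1` is the next one to be tested in this assay. It differs from compound 2 in one place: 5-cyanopyridin-2-yl in place of 4-cyanophenyl on an oxygen on an aromatic ring. Among the measured compounds shown here, since no measured step exists between compounds that differ in this way, the size of the change cannot be read from the data, and the expectation is a step of no size beyond the scatter, in either direction. On that basis, the step expected from compound 2 to compound 4 is a step that the limit leaves unreadable from compound 2 to compound 4. Compound 4 is therefore estimated to give 70 ug/mL in this assay, within a range from 35 ug/mL to 150 ug/mL, most probably reported again as a limit.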

Compound 4, half-maximal inhibitory concentration: > 62.5 ug/mL
Compound 4: a limit, no number; the forecaster's own chance of this, stated with the estimate: 80%; the middle value does not contradict the limit.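

Compound 2 and compound 4 both return a limit rather than a number in this assay, so no step can be read from compound 2 to compound 4: the limit of > 62.5 ug/mL in this assay, at which 2 of the 4 values shown sit. The compounds shown leave open what effect, if any, 5-cyanopyridin-2-yl in place of 4-cyanophenyl has on this read-out.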